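Chlorine Added to the Ring Core: Two Benzyl Isomers Compared

A few compounds are considered here, and "the series" means these few. Any claim that something is new, unique, unknown or untested is made for them only; others in the source may bear on it.

Measured compounds:
compound 1 `ClCc1ccc(Cn2cnc3c(Cl)ncnc32)cc1`, 1170 nM
compound 2 `ClCc1cccc(Cn2cnc3ncnc(Cl)c32)c1`, 36300 nM
compound 3 `ClCc1ccc(Cn2cnc3c(Cl)nc(Cl)nc32)cc1`, 30900 nM

The three measured compounds were tested in a functional assay on SF-539 cells (Homo sapiens) for cytotoxicity, read by sulforhodamine B assay, with a stated time of 48 h; a lower number here means a stronger inhibitor of growth, a higher number a weaker inhibitor of growth. Compound 1 gives 1170 nM, the lowest number among the three. Compound 3 carries one more chlorine than compound 1; the change is chloro in place of hydrogen on an aromatic carbon, and the step is a 26-fold higher number from compound 1 to compound 3 (1.42 log units; beyond the scatter). Compound 2 has the same atoms as compound 1 joined differently; the difference between the two cores is not broken down here. In this assay compound 2 gives 36300 nM, and compound 3 gives 30900 nM; these two numbers lie within the usual scatter of each other, so no order between them can be read.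

Compound 4 `ClCc1cccc(Cn2cnc3nc(Cl)nc(Cl)c32)c1` has not yet been measured. It stands to compound 2 as compound 3 stands to compound 1: the change is chloro in place of hydrogen on an aromatic carbon, the same change as before, at a place described in the same words. For the measured compounds named here, the one measured example of this change is the step from compound 1 to compound 3, which was large. Compound 2 already gives a high number, so whether the same change produces an equally large step from a weaker starting point cannot be known from these three compounds alone. The step is expected to be a 2.8-fold higher number from compound 2 to compound 4 (0.44 log units; beyond the scatter), somewhat smaller than the earlier step, because compound 2 gives 36300 nM, a number that is already high. Compound 4 is therefore estimated to give 100000 nM in this assay, with a range from 25000 nM to 400000 nM, and a real chance that only a limit is reported.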

Compound 4, concentration for total growth inhibition: 460 nM
Compound 4: middle estimate off by 220-fold (2.34 log units), on the high side; measured number below the stated range.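

In this assay, chloro in place of hydrogen on an aromatic carbon, here between two ring nitrogen atoms, gives a 79-fold lower number from compound 2 to compound 4 (1.90 log units; beyond the scatter), so on this core the added chlorine goes with a much stronger inhibitor of growth. The same change went the opposite way on the other core, and the two steps differ by far more than repeated measurements would explain: the same change on two cores in this assay, a 26-fold higher number (1.42 log units; beyond the scatter) from compound 1 to compound 3 and a 79-fold lower number (1.90 log units; beyond the scatter) from compound 2 to compound 4, 2100-fold (3.32 log units) apart, beyond the scatter of two such steps

This shows that, in this series, the size and even the direction of this change do not carry from one core to the other, so a step measured on one core is a poor guide to the same step on the other; it does not show why the two cores behave differently, which part of the difference between them matters, or that a rule would hold beyond these two pairs of compounds.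

As far as these compounds go, it remains open whether an amine or a methoxy group on that same carbon would also move the number in opposite directions on the two cores. Also open, from the compounds shown here alone, is whether the reversal belongs to the chloro group itself or would appear with any group placed there.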